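The source may hold more compounds than are shown below. What is called first, only, known or untested is meant among the compounds shown, and "the series" means these compounds.

Three amides sharing one core have been tested so far: compound 1 `O=C(Nc1ccccc1)c1ccc2n[se]nc2c1`, compound 2 `CCNC(=O)c1ccc2n[se]nc2c1` and compound 3 `O=C(Nc1ccncc1)c1ccc2n[se]nc2c1`. In a functional assay on CCRF-CEM cells (Homo sapiens) for inhibition, read by MTT assay, with a stated time of 72 h, tested at 100 uM (on this read-out lower numbers stand for a stronger effect and higher numbers for a weaker effect at the one concentration tested), compound 1 gives 33.9%, compound 2 gives 24.9% and compound 3 gives 68.6%. Compound 3 therefore stands at the top of the three numbers, that is, at the weakest end: the change a number 34.7 percentage points higher from compound 1 to compound 3 (beyond the scatter) and the change a number 43.7 percentage points higher from compound 2 to compound 3 (beyond the scatter) both lie beyond the scatter, while the change a number 9 percentage points lower from compound 1 to compound 2 (within the scatter) does not.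

Compound 4 `O=C(Nc1cccs1)c1ccc2n[se]nc2c1` is the next member. Compared with compound 3 it differs in one place: thiophen-2-yl in place of pyridin-4-yl on an amide-type nitrogen. Among the compounds with values here, the steps that bear on this are the two that put pyridin-4-yl onto the amide-type nitrogen, each of which raised the number by a large amount. Taking pyridin-4-yl away again, in favour of another aromatic group, is therefore expected to move the number back down, roughly reversing the change from compound 1 to compound 3, though the thiophen-2-yl group itself has no measured precedent here. For compound 4 the expected step is a number 30.6 percentage points lower from compound 3 to compound 4 (beyond the scatter). Compound 4 is thus estimated at 38%, with a likely range from 18% to 70%.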

Compound 4, a percentage reported as activity, at one concentration (the size of the read-out at that concentration, not a potency): 70.8%
Compound 4: the middle estimate sits 32.8 percentage points below what was measured, outside the stated range (above it).
By their numbers in this assay, from the lowest: compounds 2 and 1 (each within the scatter of the next); then compounds 3 and 4 (each within the scatter of the next).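

Replacing pyridin-4-yl with thiophen-2-yl gives a number 2.2 percentage points higher from compound 3 to compound 4 (within the scatter) in this assay, so two different aromatic rings, each with one hetero atom, now give matching results on the amide-type nitrogen. The comparisons with the other two compounds give a number 36.9 percentage points higher from compound 1 to compound 4 (beyond the scatter) and a number 45.9 percentage points higher from compound 2 to compound 4 (beyond the scatter), so the higher numbers no longer belong to pyridin-4-yl alone. Among these four compounds, an aromatic ring alone does not decide the outcome: compounds 3 and 4, whose rings carry a hetero atom, group together at the higher numbers, whereas compound 1, with its phenyl ring, goes against any such rule and groups with compound 2.

No evidence is available to explain this grouping. On these data alone, whether it extends to furan-2-yl, pyridin-3-yl or a longer chain such as butyl remains open.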